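Removing a phenyl from two related compounds

The source may report more compounds than this note shows. Statements on the series, on what has been measured and on what is new or still open speak of the compounds shown alone.

Measured compounds:
compound 1, `CC(CC(=N)S)n1ncccc1=O`: 38.8%
compound 2, `CC(CC(=N)S)n1nc(-c2ccccc2)ccc1=O`: 15.5%
compound 3, `N=C(S)CCn1nc(-c2ccccc2)c2ccccc2c1=O`: 73.3%

Of the compounds shown here, three have been tested in a functional assay on the whole organism (stomach) for inhibition, with Rattus norvegicus as the target, at a dose of 100 mg/kg by the intraduodenal route; on this read-out lower numbers stand for less inhibition and higher numbers for more inhibition at the one dose given (going by the name of the read-out). Compound 2 `CC(CC(=N)S)n1nc(-c2ccccc2)ccc1=O` carries a phenyl on its core and gives 15.5%. Compound 1 `CC(CC(=N)S)n1ncccc1=O` differs from it in one place, (hydrogen in place of phenyl on an aromatic carbon), and in this assay compound 1 gives 38.8%. That change made a step of a number 23.3 percentage points higher from compound 2 to compound 1 (beyond the scatter). Compound 3 `N=C(S)CCn1nc(-c2ccccc2)c2ccccc2c1=O` rests on a different core; how the core of compound 2 and the core of compound 3 differ is not broken down here. In this assay compound 3 gives 73.3%, the highest of the three numbers, beyond the scatter from both others.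

Compound 4 `N=C(S)CCn1ncc2ccccc2c1=O` has not yet been measured. It arises from compound 3 by hydrogen in place of phenyl on an aromatic carbon. Among the measured compounds shown here, this is the same kind of change as the one from compound 2 to compound 1, not the same: here the aromatic carbon sits in a ring that is part of a fused or bridged system of two rings, ortho to a fused ring, meta to a fused ring, and meta to a group of 5 heavy atoms rather than 6 heavy atoms. If the change acts as in the earlier step, compound 4 should come out higher than compound 3, though a percentage of inhibition cannot rise without bound. Compound 4 is therefore expected to give about 82%, with a likely range from 55% to 96%. That estimate means an expected step of a number 8.7 percentage points higher from compound 3 to compound 4 (within the scatter), smaller than the earlier one because compound 3 already stands at 73.3%.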

Compound 4, a percentage reported as inhibition, in the whole organism at one dose (the size of the read-out at that dose, not a potency): 58.3%
Compound 4: middle estimate off by 23.7 percentage points, on the high side; the range from low to high includes it.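

In this assay, among the compounds shown here, replacing the phenyl with a hydrogen on the core of compound 3 gave a number 15 percentage points lower from compound 3 to compound 4 (beyond the scatter), so here the phenyl-bearing compound is the one with the higher number. On the earlier core the same swap went the other way, which means the effect of this change did not carry over from one core to the other, and its direction depends on the compound that receives it: the same change on two cores in this assay, a number 23.3 percentage points higher (beyond the scatter) from compound 2 to compound 1 and a number 15 percentage points lower (beyond the scatter) from compound 3 to compound 4, 38.3 percentage points apart, beyond the scatter of two such steps

For the compounds shown here, this does not show which feature of the two cores sets the steps apart, and it gives no rule for a third core, as there are only two pairs, each read at one dose in a single whole-animal assay. The compounds shown leave open whether the phenyl matters for its size, its ring or something else, and a methyl or an amine on the same aromatic carbon of each core would help to separate these possibilities. They also leave open how the two steps would look with a longer chain on the ring nitrogen, and whether they would keep their opposite directions at other doses.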